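Replacing the carbamoyl side chain on the shared core

The source may hold more compounds than are shown below. What is called first, only, known or untested is meant among the compounds shown, and "the series" means these compounds.

Three compounds carry numbers in a functional assay (B cells) with Mus musculus as the target; on this read-out lower numbers stand for an effect already at smaller amounts and higher numbers for an effect only at larger amounts of compound. Compound 1 `C=CCn1c(=O)n(CCC(CCOCc2ccccc2)CCOCc2ccccc2)c2nc(N)nc(O)c21` gives 7 uM in this assay, and compound 2 `C=CCn1c(=S)n(C2OC(CO)[C@@H](O)C(O)[C@H]2O)c2nc(N)nc(O)c21` gives 1 uM in this assay. Compound 3 `NC(=O)Cn1c(=O)n(C2OC(CO)[C@@H](O)[C@H]2O)c2nc(N)nc(O)c21` gives 190 uM in this assay, the highest of the three numbers, with gaps to compound 1 and compound 2 that lie beyond the scatter. Compound 4 `CN(C)CCCn1c(=O)n(C2OC(CO)[C@@H](O)[C@H]2O)c2nc(N)nc(O)c21` is not yet measured. It differs from compound 3 in one place: 2-(dimethylamino)ethyl in place of carbamoyl on a saturated chain carbon bound to an aromatic nitrogen. Among the compounds with values here, no pair of measured compounds differs in one place, so no single-point step scales this change. Compound 3 stands well apart from the other two, and a move toward lower numbers in this assay is expected for compound 4, of uncertain size. Compound 4 is estimated at 30 uM in this assay, within 5 uM to 150 uM, an expected step of a 6.3-fold lower number from compound 3 to compound 4 (0.80 log units; beyond the scatter).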

Compound 4, concentration for half-maximal effect: 194 uM
For compound 4 the middle estimate is 6.5-fold (0.81 log units) below the measured one; the whole stated range lies below it.
By their numbers in this assay, from the lowest: compound 2; then compound 1; then compounds 3 and 4 (each within the scatter of the next).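

In this assay, 2-(dimethylamino)ethyl in place of carbamoyl on a saturated chain carbon bound to an aromatic nitrogen gives a 1.0-fold higher number from compound 3 to compound 4 (0.01 log units; within the scatter). Within the data shown here, this is the first single-place comparison, and the two side chains read alike despite their different heavy-atom and hydrogen-bond donor counts. No supporting data bear on why they read alike. Still open, going by these compounds, is whether a carboxylic acid or a primary amine at this place would separate from these two groups.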